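Halogen swap on the aryl ketone of a pyrazolyl enone series

The compounds below may be only part of what the source reports. "The series", "measured", "known", "first", "only" and "open" are said of these compounds alone.

Measured compounds:
compound 1 `COc1ccc(-c2cc(/C=C/C(=O)c3ccc(OC)c(OC)c3)[nH]n2)cc1`: 90%
compound 2 `COc1cc(-c2cc(/C=C/C(=O)c3ccc(Cl)c(Cl)c3)[nH]n2)cc(OC)c1OC`: 91%
compound 3 `COc1cc(C(=O)/C=C/c2cc(-c3cc(OC)c(OC)c(OC)c3)n[nH]2)cc(OC)c1OC`: 84%

All three were run in a functional assay on MDA-MB-468 cells (Homo sapiens) for cytotoxicity, read by sulforhodamine B assay, with a stated time of 48 h, tested at 0.1 uM; a lower number here means a stronger effect, a higher number a weaker effect of the compound at the concentration tested. Compound 1 gives 90%, compound 2 gives 91%, and compound 3 gives 84%. Compound 2 carries the largest of the three numbers, yet compound 1 sits one point away and compound 3 seven points away, both within the usual scatter, so the three compounds are not separated by these data. Among the compounds with values here, no pair among them differs in one place only, so no single structural step has been measured in this assay.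

The next compound, compound 4 `COc1cc(-c2cc(/C=C/C(=O)c3ccc(F)c(F)c3)[nH]n2)cc(OC)c1OC`, differs from compound 2 in one place:

3,4-difluorophenyl in place of 3,4-dichlorophenyl on a carbonyl carbon

Within the data shown here, for this change no measured step exists to lean on. Among the measured compounds shown here, the only information is that compounds 1, 2 and 3, with quite different substituents around the shared core, all land within the scatter of one another in this assay. On that basis the expected step from compound 2 to compound 4 is a number 1 percentage points lower from compound 2 to compound 4 (within the scatter), that is, no change beyond the scatter in either direction. Compound 4 is therefore estimated at 90% in this assay, with a likely range from 78% to 100%.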

Compound 4, a percentage reported as activity, at one concentration (the size of the read-out at that concentration, not a potency): 94%
Compound 4: the middle estimate sits 4 percentage points below what was measured; the range from low to high includes it.
By their numbers in this assay, from the lowest: compounds 3, 1, 2 and 4 (each within the scatter of the next).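

Within the data shown here, the exchange of 3,4-dichlorophenyl for 3,4-difluorophenyl on the carbonyl carbon is the only single-place step available in this assay and reads a number 3 percentage points higher from compound 2 to compound 4 (within the scatter) with the rest of compound 2 held fixed. At the concentration tested, this position therefore does not separate the two dihalophenyl groups, a statement that compounds 1, 2 and 3 could not support on their own: no two of them differ in one place only, and their closeness could have hidden opposing effects of several differences. Nothing measured here gives a reason for this step or a property of either group that bears on it.

Still open, from the compounds shown here alone, is whether a carboxylic acid or an amine on the phenyl ring at this carbonyl carbon, or a longer chain in place of that ring, would give a step beyond the scatter. A reading at one concentration also leaves open whether compound 2 and compound 4 would show a stronger or weaker effect relative to each other at higher concentrations.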